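Naphthalen-2-yl in place of 4-methoxyphenyl

The source may hold more compounds than are shown below. What is called first, only, known or untested is meant among the compounds shown, and "the series" means these compounds.

Compound 1 `COc1ccc(-n2c(SCc3ccccc3)nnc2-c2cc(OC)c(OC)c(OC)c2)cc1`: 42400 nM
Compound 2 `COc1ccc(C(=O)CSc2nnc(-c3cc(OC)c(OC)c(OC)c3)n2-c2ccc(OC)cc2)cc1`: > 60000 nM (a limit)

Both compounds were tested in a functional assay on HCT-116 cells (Homo sapiens) for inhibition, read by MTT assay, with a stated time of 48 h (on this read-out higher numbers stand for weaker inhibition and lower numbers for stronger inhibition), and in that test compound 1 gives 42400 nM.

Compound 2 stands at > 60000 nM, which is a limit of the assay and not a number.

Compound 3 `COc1ccc(-n2c(SCC(=O)c3ccc4ccccc4c3)nnc2-c2cc(OC)c(OC)c(OC)c2)cc1` is built from compound 2 with one change, naphthalen-2-yl in place of 4-methoxyphenyl on a carbonyl carbon.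

Among the measured compounds shown here, only one measured step bears on this change, and it involves a different swap at the same end of the molecule. It is an at least 1.4-fold higher number from compound 1 to compound 2 (0.15 log units; that floor lies within the scatter), with (4-methoxyphenyl)carbonyl in place of phenyl on a saturated chain carbon bound to a sulfur. For the measured compounds named here, no measured pair tests naphthalen-2-yl itself, and the starting point is only a limit.

Going by the values given here, with an at least 1.4-fold higher number from compound 1 to compound 2 (0.15 log units; that floor lies within the scatter) as the sole guide, no step beyond the scatter is expected in this assay, in either direction, and another limit would be no surprise.

The estimated change is an at least 1.2-fold lower number from compound 2 to compound 3 (0.07 log units; that floor lies within the scatter).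

For compound 3 the expected value is 50000 nM, with an estimated range from 15000 nM to 120000 nM.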

Compound 3, half-maximal inhibitory concentration: > 60000 nM
Compound 3: only a limit was reported (the forecaster's own chance of this, stated with the estimate: 50%); middle value at least 1.2-fold (0.07 log units) from the limit.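

With naphthalen-2-yl in place of 4-methoxyphenyl on the carbonyl carbon, compound 3 joins compound 2 as a limit, so the step between them cannot be read: the limit of > 60000 nM in this assay, at which 2 of the 3 values shown sit. The swap brings two six-membered aromatic rings of carbon only in place of one and leaves no hydrogen-bond acceptor in the group, yet in this assay it still yields no number that can be placed on the scale, which shows that a second (aryl)carbonyl group gives the same kind of result as the first. Set against the one compound with a real number, the result is an at least 1.4-fold higher number from compound 1 to compound 3 (0.15 log units; that floor lies within the scatter), so these compounds show no step beyond the scatter for a (naphthalen-2-yl)carbonyl group in place of phenyl on the saturated chain carbon bound to a sulfur.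

On these data alone, how far above the limit compound 2 and compound 3 really lie stays open, as does any order between them. Also open, as far as these compounds go, is whether an amine or a carboxylic acid on that saturated chain carbon would give a clearly lower number than compound 1.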